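The compounds below may be only part of what the source reports. "The series", "measured", "known", "first", "only" and "open" are said of these compounds alone.

Measured so far in a functional assay on Ehrlich cells (Mus musculus) for cytotoxicity, read by trypan blue exclusion, with a stated time of 2 h, tested at 25 ug/mL; on this read-out lower numbers stand for a weaker effect and higher numbers for a stronger effect at the one concentration tested:
- compound 1 `N#CC1=C(N)N(c2ccc(S(N)(=O)=O)cc2)C2=C(CCCC2)C1c1ccccc1O`: 40%
- compound 2 `COc1ccc(C2C(C#N)=C(N)N(c3ccc(S(N)(=O)=O)cc3)C3=C2CCCC3)cc1`: 90%

Compound 2 stands highest of the two numbers in this assay; its nearest neighbour is compound 1, and the step of a number 50 percentage points higher from compound 1 to compound 2 (beyond the scatter) is large and lies beyond the scatter. That step is the only one measured, and it swapped 2-hydroxyphenyl for 4-methoxyphenyl on a saturated ring carbon of the shared core.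

Compound 3 `N#CC1=C(N)N(c2ccc(S(N)(=O)=O)cc2)C2=C(CCCC2)C1c1ccccc1Cl` has not been measured. Its difference from compound 2 is 2-chlorophenyl in place of 4-methoxyphenyl on a saturated ring carbon. For the measured compounds named here, the measured step bears on this only in part: it concerns the same saturated ring carbon and shows that the group there can move the read-out strongly, but no measured compound carries 2-chlorophenyl, and nothing shows whether 2-chlorophenyl behaves like 2-hydroxyphenyl or like 4-methoxyphenyl. Since 4-methoxyphenyl leaves, and compound 1 without it gave 40%, a downward step a number 25 percentage points lower from compound 2 to compound 3 (beyond the scatter) is expected, its size uncertain. Compound 3 is therefore estimated at 65%, with a range from 35% to 90%.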

Compound 3, a percentage reported as activity, at one concentration (the size of the read-out at that concentration, not a potency): 0%
Estimate against measurement, compound 3: 65 percentage points above, and the stated range ends above it.
By their numbers in this assay, from the lowest: compound 3; then compound 1; then compound 2.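

In this assay, the group on the saturated ring carbon can pull the read-out down as strongly as it can raise it: with 2-chlorophenyl in place of 4-methoxyphenyl there is a number 90 percentage points lower from compound 2 to compound 3 (beyond the scatter), which puts compound 3 lowest of the three. The smaller change on the aromatic carbon also matters, since chloro in place of hydroxy gives a number 40 percentage points lower from compound 1 to compound 3 (beyond the scatter), so 2-hydroxyphenyl is not the bottom of the range at this position and one group on that aromatic ring separates two clearly different results. Nothing available on these compounds accounts for either drop.

As far as these compounds go, whether the loss follows the chlorine itself or its place on the aromatic ring stays open, as 4-methoxyphenyl and 2-chlorophenyl differ in both the group and where it stands. Also open, from the compounds shown here alone, is where a plain phenyl, or a phenyl bearing an amine or a carboxylic acid, would fall on the same saturated ring carbon within the wide span set by compound 2 and compound 3.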